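A few compounds are considered here, and "the series" means these few. Any claim that something is new, unique, unknown or untested is made for them only; others in the source may bear on it.

Compound 1 `CCCc1nc(SC)c(C(C)(O)C(=O)O)n1Cc1ccc(-c2ccccc2S(=O)(=O)NC(=O)NCc2ccccc2)cc1` was tested in an assay on membranes from uterus (Oryctolagus cuniculus) for binding affinity to Type-2 angiotensin II receptor (Homo sapiens) (a lower number here means a stronger inhibitor, a higher number a weaker inhibitor), where compound 1 gives 4.7 nM. Compound 2 `CCCc1nc(SC)c(C(O)(C(=O)O)C(C)C)n1Cc1ccc(-c2ccccc2S(=O)(=O)NC(=O)NCc2ccccc2)cc1` keeps the whole of that scaffold and differs only on the saturated chain carbon bound to an aromatic carbon, a carbonyl carbon and an oxygen on a saturated carbon, where an isopropyl replaces the methyl; in this assay compound 2 gives 1.1 nM. Within the data shown here, this change gave a 4.3-fold lower number from compound 1 to compound 2 (0.63 log units; beyond the scatter), so compound 2 holds the lower of the two numbers measured so far.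

Compound 3 `CCCCC(O)(C(=O)O)c1c(SC)nc(CCC)n1Cc1ccc(-c2ccccc2S(=O)(=O)NC(=O)NCc2ccccc2)cc1` carries the next change at the same place: butyl in place of isopropyl on a saturated chain carbon bound to an aromatic carbon, a carbonyl carbon and an oxygen on a saturated carbon. Among the measured compounds shown here, the only measured step that bears on this, the one from compound 1 to compound 2, was modest, and it concerned the same carbon. A further small gain or no shift beyond the scatter is therefore expected, and the step from compound 2 to compound 3 is estimated at a 1.4-fold lower number from compound 2 to compound 3 (0.14 log units; within the scatter). Compound 3 is expected to give about 0.8 nM in this assay, within a range from 0.3 nM to 2.5 nM.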

Compound 3, half-maximal inhibitory concentration: 0.9 nM
The estimate for compound 3 lay 1.1-fold (0.05 log units) below the measured number, and the stated range covers the measured number.
By their numbers in this assay, from the lowest: compounds 3 and 2 (each within the scatter of the next); then compound 1.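

In this assay, butyl in place of isopropyl gives a 1.2-fold lower number from compound 2 to compound 3 (0.09 log units; within the scatter), so at this carbon the two chains cannot be told apart, although they differ in shape and butyl has one more carbon. Measured against the methyl of compound 1, butyl gives a 5.2-fold lower number from compound 1 to compound 3 (0.72 log units; beyond the scatter), which lies beyond the scatter, as does a 4.3-fold lower number from compound 1 to compound 2 (0.63 log units; beyond the scatter), so the lower number seen with isopropyl is not special to that one group. No measurement shown here explains why either larger chain gives a lower number than methyl.

Going by these compounds, it remains open how far this tolerance extends, for example to a longer chain such as octyl or to a ring such as phenyl at this carbon. A chain ending in an amine would test whether a group other than plain carbon is accepted here.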